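The source may hold more compounds than are shown below. What is called first, only, known or untested is meant among the compounds shown, and "the series" means these compounds.

Measured so far:
Compound 1 `COc1cc(C(=O)c2sc3ccccc3c2-c2ccc(Cl)cc2)cc(OC)c1OC` gives 3700 nM in a functional assay on Jurkat cells (Homo sapiens) for antiproliferative activity, read by MTT assay, with a stated time of 72 h; a lower number here means a stronger inhibitor, a higher number a weaker inhibitor.
Compound 2 `COc1ccc(-c2c(C(=O)c3cc(OC)c(OC)c(OC)c3)sc3ccccc23)cc1` gives 1600 nM in this assay.
Compound 3 `COc1ccc(OC)c(-c2c(C(=O)c3cc(OC)c(OC)c(OC)c3)sc3ccccc23)c1` gives only a limit, > 10000 nM in this assay.

Compound 2 has the lowest number of the three, with compound 1 showing a 2.3-fold lower number from compound 1 to compound 2 (0.36 log units; beyond the scatter). Compound 4 `COc1ccc(Nc2c(C(=O)c3cc(OC)c(OC)c(OC)c3)sc3ccccc23)cc1` differs from compound 2 only in the group attached to the shared core: (4-methoxyphenyl)amino in place of 4-methoxyphenyl on an aromatic carbon. Among the measured compounds shown here, no measured step changes this attachment itself; the nearest comparisons, a 2.3-fold lower number from compound 1 to compound 2 (0.36 log units; beyond the scatter) and an at least 6.2-fold higher number from compound 2 to compound 3 (0.79 log units; beyond the scatter), only show that this position responds modestly to changes in the aryl group. Inserting a linking nitrogen is a different kind of change, so the direction is uncertain. Compound 4 is expected to give 2500 nM, between 700 nM and 9000 nM, which would mean a 1.6-fold higher number from compound 2 to compound 4 (0.19 log units; within the scatter).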

Compound 4, half-maximal inhibitory concentration: 3500 nM
Estimate against measurement, compound 4: 1.4-fold (0.15 log units) below; the range from low to high includes it.
By their numbers in this assay, from the lowest: compound 2; then compounds 4 and 1 (each within the scatter of the next). At a limit, above all of these: compound 3.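

Replacing 4-methoxyphenyl with (4-methoxyphenyl)amino, which brings in a hydrogen-bond donor, is tolerated with only a modest loss: a 2.2-fold higher number from compound 2 to compound 4 (0.34 log units; beyond the scatter). The same group cannot be told apart from 4-chlorophenyl, with a 1.1-fold lower number from compound 1 to compound 4 (0.02 log units; within the scatter). Against 2,5-dimethoxyphenyl the step, an at least 2.8-fold lower number from compound 3 to compound 4 (0.45 log units; beyond the scatter), is only a bound: the limit of > 10000 nM in this assay, at which 1 of the 4 values shown sits.

The compounds shown leave open how a methylated amine, an ether oxygen or a methylene link would compare at this position. They also leave open whether a longer chain carrying the 4-methoxyphenyl ring would be tolerated here.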